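Nitro for methyl on the sulfonyl aryl of the piperidinone series

This account rests on a few compounds, and the source may have more. Where it says the series, first, only, none or still open, it means among the compounds named here.

Values in a functional assay on QGY-7703 cells (Homo sapiens) for cytotoxicity, read by MTT assay, with a stated time of 24 h; on this read-out lower numbers stand for stronger inhibition and higher numbers for weaker inhibition:
compound 1, `Cc1ccc(S(=O)(=O)N2C/C(=C\c3ccncc3)C(=O)/C(=C/c3ccccc3F)C2)cc1`: > 20000 nM.
compound 2, `O=C1/C(=C/c2ccncc2)CN(S(=O)(=O)c2ccc([N+](=O)[O-])cc2)C/C1=C\c1ccccc1F`: 8800 nM.
compound 3, `Cc1ccc(S(=O)(=O)N2C/C(=C\c3ccncc3)C(=O)/C(=C/c3ccccc3C(F)(F)F)C2)cc1`: 5090 nM.

Compound 1 gives > 20000 nM, which is a limit of the assay, not a number. Compound 2 differs from compound 1 by nitro in place of methyl on an aromatic carbon, and the step is an at least 2.2-fold lower number from compound 1 to compound 2 (0.35 log units; beyond the scatter), bounded on one side because compound 1 sits at the limit of > 20000 nM in this assay, at which 1 of the 3 values shown sits. Compound 3 differs from compound 1 by trifluoromethyl in place of fluoro on an aromatic carbon, with the step of an at least 3.9-fold lower number from compound 1 to compound 3 (0.59 log units; beyond the scatter). Compound 3 and compound 2 lie within the scatter of each other.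

Compound 4, `O=C1/C(=C/c2ccncc2)CN(S(=O)(=O)c2ccc([N+](=O)[O-])cc2)C/C1=C\c1ccccc1C(F)(F)F`, is not yet measured. It differs from compound 3 by nitro in place of methyl on an aromatic carbon; the place lines of this change and of the change from compound 1 to compound 2 read the same, so this is the same change on a core that differs by the fluoro to trifluoromethyl exchange. Resting on the step of an at least 2.2-fold lower number from compound 1 to compound 2 (0.35 log units; beyond the scatter) seen from compound 1 to compound 2, the step from compound 3 to compound 4 is expected to be about a 2.0-fold lower number from compound 3 to compound 4 (0.31 log units; beyond the scatter), with room for a smaller step since the earlier one is only a lower bound. Compound 4 is thus estimated at 2500 nM in this assay, between 900 nM and 7000 nM.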

Compound 4, half-maximal inhibitory concentration: 9730 nM
Estimate against measurement, compound 4: 3.9-fold (0.59 log units) below; measured number above the stated range.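

In this assay, nitro in place of methyl gives a 1.9-fold higher number from compound 3 to compound 4 (0.28 log units; within the scatter), so the step seen on the core of compound 1 does not carry over to the core of compound 3: the same change on two cores in this assay, an at least 2.2-fold lower number (0.35 log units; beyond the scatter) from compound 1 to compound 2 and a 1.9-fold higher number (0.28 log units; within the scatter) from compound 3 to compound 4, at least 4.3-fold (0.63 log units) apart, beyond the scatter of two such steps

The paired exchange, trifluoromethyl in place of fluoro, gives a 1.1-fold higher number from compound 2 to compound 4 (0.04 log units; within the scatter) on the nitro-bearing core and likewise does not repeat what was seen on the methyl-bearing core: the same change on two cores in this assay, an at least 3.9-fold lower number (0.59 log units; beyond the scatter) from compound 1 to compound 3 and a 1.1-fold higher number (0.04 log units; within the scatter) from compound 2 to compound 4, at least 4.3-fold (0.63 log units) apart, beyond the scatter of two such steps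

Compound 1 gives > 20000 nM, which is a limit and not a number, so both gaps are known from one side only, and these four compounds show that the change depends on the core without showing why: the limit of > 20000 nM in this assay, at which 1 of the 4 values shown sits.

Going by these compounds, it remains open how a methoxy or an amine in place of the nitro on the sulfonyl aryl would behave on these two cores. On these data alone, it also remains open whether a chloro in place of the fluoro would follow compound 2 or compound 1 when the sulfonyl aryl is varied.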